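Swapping a Trifluoroethyl Group on Compound 3

A few compounds are considered here, and "the series" means these few. Any claim that something is new, unique, unknown or untested is made for them only; others in the source may bear on it.

compound 1 `CC(=O)NCc1ncc2cc(COc3ccc(C(=O)NCc4cccnc4)cc3)n(CCC3CCCCC3)c2n1` gives 77 nM
compound 2 `O=C(NCc1cccnc1)Nc1ccc(CNC(=O)c2ccc(CN3CCNCC3)cc2)cc1` gives 137 nM
compound 3 `C[C@H](NC(=O)CC(F)(F)F)c1ccc(NC(=O)[C@H]2C[C@@H]2c2cccnc2)cc1` gives 18 nM

In a functional assay on COR-L23 cells (Homo sapiens) for antiproliferative activity, read by CellTiter-Glo, with a stated time of 4 days (on this read-out higher numbers stand for weaker inhibition and lower numbers for stronger inhibition), compound 3 has the lowest number of the three (18 nM) and stands beyond the scatter from both other compounds. Compound 4 `C[C@H](NC(=O)[C@@H]1CCCN1C)c1ccc(NC(=O)[C@H]2C[C@@H]2c2cccnc2)cc1` has not yet been measured. It carries 1-methylpyrrolidin-2-yl in place of 2,2,2-trifluoroethyl on a carbonyl carbon. Among the measured compounds shown here, no measured pair differs in one place, so the data offer no direct precedent for this change. A small rise in this assay is expected, with no clear move beyond the scatter. The estimate is a 1.7-fold higher number from compound 3 to compound 4 (0.22 log units; within the scatter) toward weaker inhibition. For compound 4 the expected value is 30 nM (9 nM to 100 nM).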

Compound 4, half-maximal inhibitory concentration: 11 nM
Estimate against measurement, compound 4: 2.7-fold (0.44 log units) above; the measured number falls inside the stated range.
By their numbers in this assay, from the lowest: compounds 4 and 3 (each within the scatter of the next); then compounds 1 and 2 (each within the scatter of the next).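

In this assay, putting 1-methylpyrrolidin-2-yl in place of 2,2,2-trifluoroethyl on the carbonyl carbon gives a 1.6-fold lower number from compound 3 to compound 4 (0.21 log units; within the scatter). This first one-place comparison shows that the position tolerates a five-membered ring with a nitrogen and a defined stereocentre as well as the open 2,2,2-trifluoroethyl group. No measurement here explains this result. The compounds shown leave open whether the opposite stereoisomer, the ring without its methyl group, or an all-carbon cyclopentyl ring would read alike. They also leave open how a carboxylic acid or a longer chain would fare here.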